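The source may hold more compounds than are shown below. What is called first, only, known or untested is meant among the compounds shown, and "the series" means these compounds.

Within the data shown here, in a functional assay (a higher number here means a weaker inhibitor, a lower number a stronger inhibitor), compound 1 `CC(C)=CCOc1cc(O)c2c(c1)OC(c1ccc(F)cc1)CC2=O` gives 6060 nM and compound 2 `CC(C)=CCOc1cc(O)c2c(c1)OC(c1cccc(Br)c1)CC2=O` gives 4040 nM, so compound 2 stands within the scatter of the only other compound measured. Compound 3 `CC(C)=CCOc1cc(O)c2c(c1)OC(c1ccc(Br)cc1)CC2=O` differs from compound 2 by a single swap: 4-bromophenyl in place of 3-bromophenyl on a saturated ring carbon, with 4-bromophenyl in place of 3-bromophenyl on a saturated ring carbon. Among the measured compounds shown here, the one measured step at that carbon is a 1.5-fold lower number from compound 1 to compound 2 (0.18 log units; within the scatter), so no step beyond the scatter is expected in this assay. The expected step is a 1.1-fold higher number from compound 2 to compound 3 (0.05 log units; within the scatter). For compound 3 the estimated value is 4500 nM, with an expected range of 2000 nM to 10000 nM.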

Compound 3, half-maximal inhibitory concentration: 2770 nM
The estimate for compound 3 lay 1.6-fold (0.21 log units) above the measured number; the range from low to high includes it.
By their numbers in this assay, from the lowest: compounds 3, 2 and 1 (each within the scatter of the next, the first and the last beyond it).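

Moving the bromine from 3-bromophenyl to 4-bromophenyl gives a 1.5-fold lower number from compound 2 to compound 3 (0.16 log units; within the scatter) in this assay and so does not separate these two placements. Bromo in place of fluoro on an aromatic carbon gives a 2.2-fold lower number from compound 1 to compound 3 (0.34 log units; beyond the scatter) and is the only step so far to pass the scatter, though it is modest. Nothing at hand explains this step.

From the compounds shown here alone, it remains open whether a chloro, methoxy or amine group on that phenyl ring would change the number further. One modest step also cannot show a trend across the halogens.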